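The source may hold more compounds than are shown below. What is called first, only, known or untested is meant among the compounds shown, and "the series" means these compounds.

Working notes on the series. Within the data shown here, in an ADME assay on CCRF-CEM cells (Homo sapiens) for cytotoxicity, with a stated time of 4 days (on this read-out higher numbers stand for lower toxicity in this test and lower numbers for higher toxicity in this test), compound 1 (`Cc1cn([C@@H]2O[C@H](CO[Si](C)(C)C(C)(C)C)[C@@]3(OS(=O)(=O)C=C3N)[C@H]2O[Si](C)(C)C(C)(C)C)c(=O)n(C(=O)OC(C)(C)C)c1=O`) gives 26000 nM, and compound 2 (`Cc1cn([C@@H]2O[C@H](CO[Si](C)(C)C(C)(C)C)[C@@]3(OS(=O)(=O)C=C3N)[C@H]2O[Si](C)(C)C(C)(C)C)c(=O)n(C(=O)CCCC(N)=O)c1=O`) gives 8700 nM, the lowest of the numbers so far. Compound 3 (`Cc1cn([C@@H]2O[C@H](CO[Si](C)(C)C(C)(C)C)[C@@]3(OS(=O)(=O)C=C3N)[C@H]2O[Si](C)(C)C(C)(C)C)c(=O)n(C(=O)CCCC(=O)NCc2ccccc2)c1=O`) differs from compound 2 by a single change: benzyl in place of hydrogen on an amide-type nitrogen. Among the measured compounds shown here, only one measured step bears on this: a 3.0-fold lower number from compound 1 to compound 2 (0.48 log units; beyond the scatter), a modest step with 3-carbamoylpropyl in place of tert-butoxy on a carbonyl carbon. That step brought in the amide-type nitrogen that carries the benzyl in compound 3. A single modest step is a thin guide, so in this assay a smaller step is expected, leaning towards a lower number and probably not beyond the scatter. The estimated change is a 1.7-fold lower number from compound 2 to compound 3 (0.24 log units; within the scatter). For compound 3 the expected value is 5000 nM, within an estimated range of 2000 nM to 13000 nM.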

Compound 3, half-maximal cytotoxic concentration: 8800 nM
The estimate for compound 3 lay 1.8-fold (0.25 log units) below the measured number, within the range that was stated.
By their numbers in this assay, from the lowest: compounds 2 and 3 (each within the scatter of the next); then compound 1.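

In this assay the amide-type nitrogen carries a benzyl in place of hydrogen with a 1.0-fold higher number from compound 2 to compound 3 (0.00 log units; within the scatter), so compound 2 and compound 3 stand within the scatter of each other. The earlier step, a 3.0-fold lower number from compound 1 to compound 2 (0.48 log units; beyond the scatter), lay beyond the scatter, whereas the 7 heavy atoms and the six-membered aromatic ring of carbon only brought in here leave the read-out within it, for this one substituent on this nitrogen. Nothing available explains why the number holds with benzyl on this nitrogen.

On these data alone, whether a methyl, a longer phenethyl chain or a benzyl bearing an amine on its ring would also stay within the scatter remains open. So does whether a carboxylic acid in place of the amide would.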